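The source may report more compounds than this note shows. Statements on the series, on what has been measured and on what is new or still open speak of the compounds shown alone.

Compound 3, `COc1cc(OC)c(/C=C/S(=O)(=O)Cc2ccc([N+](=O)[O-])cc2)c(OC)c1`, holds the highest of the two numbers that a functional assay on DLD-1 cells (Homo sapiens) for antiproliferative activity, read by trypan blue exclusion (a lower number here means a stronger inhibitor, a higher number a weaker inhibitor), has yielded so far: here compound 3 gives 15000 nM. Its nearest neighbour on this scale is compound 1, `COc1cc(OC)c(/C=C/S(=O)(=O)Cc2ccc(OC)c(OP(=O)(O)O)c2)c(OC)c1`, which in this assay gives 7 nM, a gap that lies well beyond the usual scatter. Compound 2, `COc1cc(OC)c(/C=C/S(=O)(=O)Cc2cc(OC)c(OC)c(OC)c2)c(OC)c1`, is also in the set, and in this assay compound 2 returns only a limit, > 20000 nM. That result is one of the values at the boundary described by the limit of > 20000 nM in this assay, at which 1 of the 3 values shown sits. The unmeasured member is compound 4, `COc1cc(OC)c(/C=C/S(=O)(=O)Cc2ccc(C(=O)O)cc2)c(OC)c1`. Compared with compound 3 the change is carboxy in place of nitro on an aromatic carbon. Going by the values given here, no pair of measured compounds shares this exact change, so the size of the step rests on expectation alone: the step from compound 3 to compound 4 is expected to be small, within the scatter, in either direction, written as no change at the digits printed from compound 3 to compound 4 (within the scatter). Compound 4 is therefore estimated to give about 15000 nM in this assay, with a plausible range from 3000 nM to 60000 nM.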

Compound 4, half-maximal inhibitory concentration: 15000 nM
Estimate against measurement, compound 4: no gap at the digits printed; the range from low to high includes it.
By their numbers in this assay, from the lowest: compound 1; then compounds 3 and 4 (each within the scatter of the next). At a limit, above all of these: compound 2.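

The step of no change at the digits printed from compound 3 to compound 4 (within the scatter) in this assay is the only single-place comparison among the compounds shown, and it gives this position its first direct reading. Of the two groups tested on an aromatic carbon para to a large group, nitro and carboxy cannot be told apart by this read-out, although they differ in their counted hydrogen-bond donors and acceptors. The 4-nitrophenyl to 4-carboxyphenyl change therefore leaves the number where it stood, and nothing among the data shown accounts for that outcome.

Going by these compounds, whether an amine, an amide or a halogen such as fluorine at this same place would also leave the number unchanged stays open. Also open, on these data alone, is whether a group placed elsewhere on this ring would move the number beyond the scatter.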